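From naphthalen-2-yl to 2-hydroxy-5-methoxyphenyl on the carbonyl carbon

The source may report more compounds than this note shows. Statements on the series, on what has been measured and on what is new or still open speak of the compounds shown alone.

In a functional assay on MCF7 cells (Homo sapiens) for cytotoxicity, read by resazurin assay, with a stated time of 3 days (a higher number here means a weaker inhibitor, a lower number a stronger inhibitor), compound 2 (`CC(C)(CNC(=O)c1ccc2ccccc2c1)CC1=C(O)C(=O)c2ccccc2C1=O`) reads 28200 nM and sits at the low end of the three measured numbers. Compound 1 (`CC(C)(CNC(=O)c1ccccc1)CC1=C(O)C(=O)c2ccccc2C1=O`) reads 37100 nM and lies within the scatter of it, while compound 3 (`CC(C)(CNC(=O)c1ccc2ccccc2c1O)CC1=C(O)C(=O)c2ccccc2C1=O`) reads 79500 nM and lies higher, beyond the scatter. Compound 4 (`COc1ccc(O)c(C(=O)NCC(C)(C)CC2=C(O)C(=O)c3ccccc3C2=O)c1`) carries 2-hydroxy-5-methoxyphenyl in place of naphthalen-2-yl on a carbonyl carbon. Among the compounds with values here, two measured steps bear on this change. The exchange of phenyl for naphthalen-2-yl gave a 1.3-fold lower number from compound 1 to compound 2 (0.12 log units; within the scatter) and so a return to one aromatic ring alone is expected to move little. Within the data shown here, the addition of hydroxy on an aromatic carbon gave a 2.8-fold higher number from compound 2 to compound 3 (0.45 log units; beyond the scatter) and is the only guide to the hydroxy of compound 4, although it was seen on another aromatic group. Among the measured compounds shown here, no measured step covers the methoxy. A small upward move is therefore expected, and the estimated step is a 2.0-fold higher number from compound 2 to compound 4 (0.29 log units; within the scatter) in this assay terms. The estimate for compound 4 is 55000 nM (expected range 22000 nM to 130000 nM).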

Compound 4, half-maximal inhibitory concentration: 39600 nM
Compound 4: middle estimate off by 1.4-fold (0.14 log units), on the high side; low and high end bracket the measured number.
By their numbers in this assay, from the lowest: compounds 2, 1, 4 and 3 (each within the scatter of the next, the first and the last beyond it).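

In this assay, 2-hydroxy-5-methoxyphenyl on the carbonyl carbon gives a 1.4-fold higher number from compound 2 to compound 4 (0.15 log units; within the scatter) and a 1.1-fold higher number from compound 1 to compound 4 (0.03 log units; within the scatter), so compound 4 cannot be told apart from either compound 2 or compound 1. Within the data shown here, a hydroxy-bearing aromatic group at this position therefore does not always separate from the unsubstituted groups, unlike the hydroxy step a 2.8-fold higher number from compound 2 to compound 3 (0.45 log units; beyond the scatter), and compound 3 remains the one compound beyond the scatter of compound 2. No measured property of these compounds bears on this difference between compound 3 and compound 4.

Going by these compounds, the separate contributions of the hydroxy and the methoxy on the phenyl ring remain open, since the two enter together in compound 4. Also open, on these data alone, is whether an amine or a carboxylic acid on that ring would bring the number clearly below that of compound 2, at 28200 nM.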